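This account rests on a few compounds, and the source may have more. Where it says the series, first, only, none or still open, it means among the compounds named here.

Working notes on the series. In a functional assay on A549 cells (Homo sapiens) for antiproliferative activity, read by MTT assay, with a stated time of 48 h (a higher number here means a weaker inhibitor, a lower number a stronger inhibitor), compound 1 (`COc1ccc(C(=O)c2ccc(OC)c3c2C=CC(C)(C)O3)c(NC(=O)CBr)c1`) gives 2460 nM, compound 2 (`COc1ccc(C(=O)c2ccc3c(c2)C=CC(C)(C)O3)c(NC(=O)CBr)c1`) gives 1980 nM and compound 3 (`CCNCC(=O)Nc1cc(OC)ccc1C(=O)c1ccc(OC)c2c1OC(C)(C)C=C2`) gives 1050 nM. Compound 2 stands within the scatter of both compound 1 and compound 3. Compound 4 (`COc1ccc(C(=O)c2ccc3c(c2)C=CC(C)(C)O3)c(NC(=O)CN(C)C)c1`) has dimethylamino in place of bromo on a saturated chain carbon bound to a carbonyl carbon. Among the measured compounds shown here, no measured pair isolates this change. For the measured compounds named here, compound 3, at 1050 nM, is the only measured compound without bromo on that chain, and it lies within the scatter of compound 2, so in this assay only a small move to a lower number is expected, possibly none beyond the scatter. The expected step is a 1.5-fold lower number from compound 2 to compound 4 (0.18 log units; within the scatter). Compound 4 is estimated at 1300 nM, with an expected range of 450 nM to 3800 nM.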

Compound 4, half-maximal inhibitory concentration: 1160 nM
Compound 4: the middle estimate sits 1.1-fold (0.05 log units) above what was measured; measured number inside the range.
By their numbers in this assay, from the lowest: compounds 3, 4, 2 and 1 (each within the scatter of the next, the first and the last beyond it).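

In this assay, dimethylamino in place of bromo on a saturated chain carbon bound to a carbonyl carbon gives a 1.7-fold lower number from compound 2 to compound 4 (0.23 log units; within the scatter), so this one-place comparison does not separate the two groups. On this core, activity at this level therefore does not depend on bromo at that carbon. No available evidence bears on this result. Still open, from the compounds shown here alone, is whether a cyclic amine such as morpholine or a carboxylic acid at that carbon would read apart from these two groups. A longer chain between the carbonyl and dimethylamino also remains untested in the compounds shown.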